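Stretching an Ethoxy Group into a Diol

This account rests on a few compounds, and the source may have more. Where it says the series, first, only, none or still open, it means among the compounds named here.

Compound 1 `O=C(N[C@@H]1CCNC1)c1cc(-c2ccc(NS(=O)(=O)c3cccc(Cl)c3Cl)cc2)nc2[nH]ncc12` is the reference point of this set. In an assay for inhibition of serine/threonine-protein kinase Sgk1 (Homo sapiens), with stated times of 30 min and 60 min, in the presence of a further agent that is not named here (on this read-out higher numbers stand for weaker inhibition and lower numbers for stronger inhibition), compound 1 gives < 1 nM, which is not a number but (the limit of < 1 nM in this assay, at which 1 of the 3 values shown sits). Compound 2 `CN1CCC(CNC(=O)c2cc(-c3ccc(NS(=O)(=O)c4cccc(Cl)c4Cl)cc3)nc3[nH]ncc23)C1` differs from it only at the amide-type nitrogen, and in this assay compound 2 gives 14 nM; the change brings an at least 14-fold higher number from compound 1 to compound 2 (1.14 log units; beyond the scatter). Compound 3 `CCOc1nc(-c2ccc(NS(=O)(=O)c3cc(Cl)ccc3F)cc2)nc2[nH]nc(C)c12` carries a different core and a different sulfonamide partner, and in this assay compound 3 gives 23 nM, a value that stands alongside compound 2 within the usual scatter.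

Compound 4 `Cc1n[nH]c2nc(-c3ccc(NS(=O)(=O)c4cc(Cl)ccc4F)cc3)nc(OCC(CO)CO)c12` is not yet measured. It differs from compound 3 by 2-hydroxy-1-(hydroxymethyl)ethyl in place of methyl on a saturated chain carbon bound to an oxygen on an aromatic ring. Among the compounds with values here, none of the measured steps touches this position; the only measured step changes the amide-type nitrogen of compound 1, and although it was large, it concerns a different part of the molecule. Within the data shown here, with no step at the ether chain to lean on, the expected change is small, and a step of a 1.3-fold higher number from compound 3 to compound 4 (0.12 log units; within the scatter) is estimated. Compound 4 is therefore expected to give about 30 nM, within a range from 10 nM to 100 nM.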

Compound 4, half-maximal inhibitory concentration: 1 nM
For compound 4 the middle estimate is 30-fold (1.48 log units) above the measured one; measured number below the stated range.
By their numbers in this assay, from the lowest: compound 4; then compounds 2 and 3 (each within the scatter of the next).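

The ether chain of compound 3 turns out to be a position where this assay responds strongly: 2-hydroxy-1-(hydroxymethyl)ethyl in place of methyl on a saturated chain carbon bound to an oxygen on an aromatic ring gives a 23-fold lower number from compound 3 to compound 4 (1.36 log units; beyond the scatter). The ethoxy group is therefore not the limit of what this position accepts, since the longer, branched 3-hydroxy-2-(hydroxymethyl)propoxy goes with much stronger inhibition while the core and the sulfonamide partner stay the same. Within the data shown here, the one earlier step concerned the amide-type nitrogen and ran towards a higher number, so this is the first step in the set that runs towards a lower one, and the first to say anything about the ether chain.

This single pair cannot separate the added chain length from the two added hydroxyl groups, and a plain propoxy chain, a 2-hydroxyethoxy chain or an amine at the chain end would be needed to tell them apart. Also open, from the compounds shown here alone, is how any such group would read at the low end of the scale, where compound 1 gives only a limit: the limit of < 1 nM in this assay, at which 1 of the 4 values shown sits.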